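Working notes on cytotoxicity in a small series

A few compounds are considered here, and "the series" means these few. Any claim that something is new, unique, unknown or untested is made for them only; others in the source may bear on it.

Measured so far:
compound 1 `O=C(/C=C/c1ccc2c(c1)B(O)OC2)c1ccccc1` — > 10 ug/mL
compound 2 `Cn1cccc1C(=O)/C=C/c1ccc2c(c1)B(O)OC2` — > 10 ug/mL
compound 3 `O=C(/C=C/c1ccc2c(c1)B(O)OC2)c1cccs1` — > 10 ug/mL

In an ADME assay on L929 cells (Mus musculus) for cytotoxicity, read by resazurin assay, with a stated time of 72 h (a lower number here means a stronger inhibitor, a higher number a weaker inhibitor), compound 1 gives > 10 ug/mL, which is a limit of the assay and not a number. Compound 2 in this assay likewise gives > 10 ug/mL, a limit. Compound 3 gives > 10 ug/mL, also a limit. Compound 1 therefore stands at the limit of > 10 ug/mL in this assay, at which 3 of the 3 values shown sit, with nothing to rank it against the other two. The three measured steps, a step that the two limits leave unreadable from compound 1 to compound 2, a step that the two limits leave unreadable from compound 1 to compound 3 and a step that the two limits leave unreadable from compound 2 to compound 3, each swap the aryl group on the carbonyl carbon, and none of them can be sized, since both ends sit at the limit.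

Compound 4 `O=C(/C=C/c1ccc2c(c1)B(O)OC2)c1ccc(-c2ccccc2)cc1` remains to be measured. Its change from compound 1 is phenyl in place of hydrogen on an aromatic carbon. Going by the values given here, no measured step touches this position, so the measured steps bear on it only in showing that every variation so far in this assay left the read-out at the limit. The expectation for compound 4 is therefore a weak inhibitor in this assay, most likely again at or near the limit, with compound 4 estimated at 15 ug/mL, in a range from 5 ug/mL to 40 ug/mL. The expected step that the limit leaves unreadable from compound 1 to compound 4 cannot be read against a limit and is taken as none beyond the scatter.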

Compound 4, half-maximal inhibitory concentration: > 10 ug/mL
Compound 4 gave a limit, no number; the forecaster's own chance of this, stated with the estimate: 65%; the middle value is on the limit's open side.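

No new step can be read: compound 1 and compound 4 both stand at a limit in this assay, so the change from hydrogen to phenyl has no measurable size, and the series offers no comparison: the limit of > 10 ug/mL in this assay, at which 4 of the 4 values shown sit.

The compounds shown leave open where compound 1, compound 2, compound 3 and compound 4 would each reach half-maximal inhibition in this assay, and whether they differ at all.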